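This account rests on a few compounds, and the source may have more. Where it says the series, first, only, none or still open, it means among the compounds named here.

Compound 1 `Clc1ncnc2c1ncn2Cc1ccccc1`: 3%
Compound 2 `Fc1ccc(Cn2cnc3c(Cl)ncnc32)cc1`: 0%

In an assay on isolated protein for inhibition of Rho-associated protein kinase 1 (Homo sapiens), tested at 30 uM (a lower number here means less inhibition, a higher number more inhibition at the concentration tested (going by the name of the read-out)), compound 1 gives 3%, the higher of the two numbers, while compound 2 gives 0%; the step of a number 3 percentage points lower from compound 1 to compound 2 (within the scatter) is within the scatter. Compound 3 `Fc1ccc(Sc2ncnc3c2ncn3Cc2ccccc2)cc1` differs from compound 1 in (4-fluorophenyl)sulfanyl in place of chloro on an aromatic carbon. Going by the values given here, the single measured step concerns a fluoro in place of hydrogen on an aromatic carbon and so does not bear on this replacement; no measured step covers it. Both measured values are low, so no step beyond the scatter is expected in this assay. Compound 3 is expected to give about 6%, between 0% and 25%. The expected step is a number 3 percentage points higher from compound 1 to compound 3 (within the scatter).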

Compound 3, a percentage reported as inhibition, at one concentration (the size of the read-out at that concentration, not a potency): 5%
Compound 3: the middle estimate sits 1 percentage points above what was measured, within the range that was stated.
By their numbers in this assay, from the lowest: compounds 2, 1 and 3 (each within the scatter of the next).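

Going by these compounds alone, compound 3 gives the first reading on this position, where the earlier step concerned only a fluoro elsewhere on the molecule. In this assay, replacing chloro (1 heavy atom) with (4-fluorophenyl)sulfanyl (8 heavy atoms, with an added aromatic ring) gives a number 2 percentage points higher from compound 1 to compound 3 (within the scatter), so this much larger group leaves the read-out within the scatter. Nothing available explains this result.

Going by these compounds, it remains open whether a smaller group at this carbon, such as an amine or a morpholine, would give a step beyond the scatter. On these data alone, it is also open whether a carboxylic acid on the added ring would do so.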